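Replacing the sulfur-bound ring of a weak growth inhibitor

This account rests on a few compounds, and the source may have more. Where it says the series, first, only, none or still open, it means among the compounds named here.

In a functional assay on SMMC-7721 cells (Homo sapiens) for inhibition, read by CCK-8 assay, with a stated time of 72 h, tested at 8 uM (a higher number here means more inhibition of growth at the concentration tested, a lower number less inhibition of growth), compound 1 `Cc1cc(C)cc(SCc2ccc(/C=C/C(=O)Nc3ccccc3N)cc2)c1` gives 7.13% and stands lowest of the three numbers at hand. Compound 2 `COc1ccc(SCc2ccc(C(=O)Nc3ccccc3N)cc2)cc1` reaches 80.1% and compound 3 `CCc1ccc(SCc2ccc(C(=O)Nc3ccccc3N)cc2)cc1` reaches 82.9% with both far beyond the scatter above compound 1. Compound 4 `Nc1ccccc1NC(=O)/C=C/c1ccc(CSc2ccc(C(F)(F)F)cn2)cc1` has not yet been measured and differs from compound 1 in one place. The change 5-(trifluoromethyl)pyridin-2-yl in place of 3,5-dimethylphenyl on a sulfur amounts to 5-(trifluoromethyl)pyridin-2-yl in place of 3,5-dimethylphenyl on a sulfur. For the measured compounds named here, the only measured step in one place a number 2.8 percentage points higher from compound 2 to compound 3 (within the scatter) exchanges one group on a ring and not a whole ring, so it bears on this change only loosely. With compound 1 at 7.13% in this assay little room remains downward, so a rise is expected, though nothing measured fixes its size. The estimated step of a number 14.9 percentage points higher from compound 1 to compound 4 (beyond the scatter) is a modest one with wide uncertainty. Compound 4 is expected at 22% within an estimated range of 5% to 60% as a working estimate.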

Compound 4, percent growth inhibition at one concentration: 20.1%
Estimate against measurement, compound 4: 1.9 percentage points above; measured number inside the range.
By their numbers in this assay, from the lowest: compound 1; then compound 4; then compounds 2 and 3 (each within the scatter of the next).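

In this assay, for the compounds shown here, the exchange of 3,5-dimethylphenyl for 5-(trifluoromethyl)pyridin-2-yl on the sulfur gives a number 13 percentage points higher from compound 1 to compound 4 (beyond the scatter), so a whole-ring replacement at this position moves the read-out, which the one earlier step, a swap of a single group on a ring, did not show. The gain is modest, and compound 4 still gives only 20.1%, so this ring exchange alone leaves growth inhibition low at the concentration tested. Nothing measured here accounts for the rise.

The ring nitrogen and the trifluoromethyl enter together, and their shares stay unseparated: a plain pyridin-2-yl or a phenyl carrying trifluoromethyl on the same sulfur would divide them. Also open, on these data alone, is how a saturated ring such as cyclohexyl would fare at this position.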